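Cyclopentyl to oxanyl ether on the shared core

The source may report more compounds than this note shows. Statements on the series, on what has been measured and on what is new or still open speak of the compounds shown alone.

Among the compounds with values here, compound 3 `O=C1OCCN1C(=O)c1ccc(OC2CCCC2)cc1` gives 120 nM in an assay on HEK293 cells for inhibition of N-acylethanolamine-hydrolyzing acid amidase (Rattus norvegicus), read by LC-MS, with a stated time of 30 min (a higher number here means a weaker inhibitor, a lower number a stronger inhibitor), and stands lowest of the three numbers so far. Compound 2 `Cc1ccc(Oc2ccc(C(=O)N3CCOC3=O)cc2)cc1` gives 6400 nM in this assay, and compound 1 `CSc1cccc(CCCCCC(=O)N2CCOC2=O)c1` gives 12800 nM. Within the data shown here, the single one-place step measured, a 53-fold lower number from compound 2 to compound 3 (1.73 log units; beyond the scatter), concerns cyclopentyl replacing 4-methylphenyl on the aromatic oxygen. Compound 4 `O=C1OCCN1C(=O)c1ccc(OC2CCOCC2)cc1` differs from compound 3 by oxan-4-yl in place of cyclopentyl on an oxygen on an aromatic ring. Among the measured compounds shown here, no measured pair exchanges cyclopentyl for a six-membered ring with one hetero atom, so no step here bears directly on this change; only the large size of the one measured step shows how much this ether position can move the number. For compound 4 a modest rise is expected, a 2.9-fold higher number from compound 3 to compound 4 (0.46 log units; beyond the scatter), estimated at 350 nM within 100 nM to 1500 nM.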

Compound 4, half-maximal inhibitory concentration: 330 nM
Compound 4: middle estimate off by 1.1-fold (0.03 log units), on the high side, within the range that was stated.
By their numbers in this assay, from the lowest: compound 3; then compound 4; then compounds 2 and 1 (each within the scatter of the next).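

Replacing cyclopentyl with oxan-4-yl on this oxygen, which adds a ring oxygen and enlarges the ring, moves the number only modestly (a 2.8-fold higher number from compound 3 to compound 4 (0.44 log units; beyond the scatter)). Compound 4 remains well below the 4-methylphenyl ether (a 19-fold lower number from compound 2 to compound 4 (1.29 log units; beyond the scatter)), so both non-aromatic rings shown, in compound 3 and compound 4, give lower numbers than the aromatic ring of compound 2. Nothing available explains the difference between the cyclopentyl and oxan-4-yl ethers.

This single step changes ring size and ring oxygen together, leaving their separate contributions open. Also open, going by these compounds, is how a piperidin-4-yl group, with its ring amine, would compare on this oxygen.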